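The source may hold more compounds than are shown below. What is called first, only, known or untested is meant among the compounds shown, and "the series" means these compounds.

Going by the values given here, compound 1, `CC(=O)Nc1ccc(-c2nn(C)/c(=N/C3CCCC(O)C3)s2)cc1`, stands at 350 ug/mL in a physicochemical assay for solubility, at pH 7.4 (on this read-out higher numbers stand for higher solubility and lower numbers for lower solubility), the only single number it has there. A second compound, compound 2, `Cn1nc(-c2ccc(S(C)(=O)=O)cc2)s/c1=N\C1CCCC(O)C1`, gives 135 ug/mL; 160 ug/mL (2 entries) in this assay, with the repeat entries the several entries of compound 2 in this assay, 135 ug/mL; 160 ug/mL (2 entries) showing how closely two runs of the same compound agree. Compound 3, `Cn1nc(-c2ccc(C(=O)NC(C)(C)CO)cc2)s/c1=N\C1CCCC(O)C1`, has not yet been measured. It differs from compound 1 in one place: (1-(hydroxymethyl)-1-methylethyl)carbamoyl in place of acetamido on an aromatic carbon. The replacement is the larger of the two groups and brings a second hydrogen-bond donor with it, but no measured pair among these compounds shows what such a change does to solubility. The step from compound 1 to compound 3, a 1.3-fold lower number from compound 1 to compound 3 (0.13 log units; within the scatter), is therefore expected to stay within the usual scatter, with no clear direction. Compound 3 is estimated at 260 ug/mL, within a range from 100 ug/mL to 650 ug/mL.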

Compound 3, solubility: 58 ug/mL
For compound 3 the middle estimate is 4.5-fold (0.65 log units) above the measured one; the whole stated range lies above it.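

In this assay, placing (1-(hydroxymethyl)-1-methylethyl)carbamoyl instead of acetamido on this aromatic carbon gives a 6.0-fold lower number from compound 1 to compound 3 (0.78 log units; beyond the scatter) and so shows that the read-out does respond to a change at this position. In this one pair, the entering group has more hydrogen-bond donors and acceptors than the group it replaces, yet the number falls, so those counts alone did not point the right way here. A gap of this size is larger than the difference between repeat runs of one compound: the several entries of compound 2 in this assay, 135 ug/mL; 160 ug/mL (2 entries).

This single pair cannot separate the reversed attachment of the amide from the added branched chain and its hydroxymethyl. On these data alone, how a simple amine or a carboxylic acid on the same aromatic carbon would read also remains open.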